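Cyano for ethyl on the aryl amide: forward estimate

The source may report more compounds than this note shows. Statements on the series, on what has been measured and on what is new or still open speak of the compounds shown alone.

Measured compounds:
compound 1 `Cc1cccc(Cn2c(CN3CCN(C(=O)c4ccc([N+](=O)[O-])cc4)CC3)nc3ccccc32)c1`, 24.3%
compound 2 `CCc1ccc(C(=O)N2CCN(Cc3nc4ccccc4n3Cc3cccc(C)c3)CC2)cc1`, 67%
compound 3 `Cc1ccc(Cn2c(CN3CCN(C(=O)C4CC4)CC3)nc3ccccc32)cc1`, 51.5%

In an assay on isolated protein for inhibition of aldehyde dehydrogenase 1A1 (Homo sapiens), read by spectrophotometry, tested at 10 uM (on this read-out lower numbers stand for less inhibition and higher numbers for more inhibition at the one concentration tested (going by the name of the read-out)), compound 2 gives 67%, the highest of the three numbers. Compound 3 gives 51.5%, beyond the scatter below it, and compound 1 gives 24.3%, the furthest away. Compound 4 `Cc1cccc(Cn2c(CN3CCN(C(=O)c4ccc(C#N)cc4)CC3)nc3ccccc32)c1` differs from compound 2 by cyano in place of ethyl on an aromatic carbon. Going by the values given here, the only measured step at this place on the ring is a number 42.7 percentage points higher from compound 1 to compound 2 (beyond the scatter), a large step. Among the compounds with values here, no measured compound carries cyano, so the size of the new step rests on that one comparison alone. A fall is expected, a number 29 percentage points lower from compound 2 to compound 4 (beyond the scatter), smaller than the measured step since the new group is not nitro. Compound 4 is estimated at 38%, with a range from 18% to 58%.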

Compound 4, a percentage reported as inhibition, at one concentration (the size of the read-out at that concentration, not a potency): 20.8%
Estimate against measurement, compound 4: 17.2 percentage points above; the range from low to high includes it.
By their numbers in this assay, from the lowest: compounds 4 and 1 (each within the scatter of the next); then compound 3; then compound 2.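

In this assay cyano in place of ethyl gives a number 46.2 percentage points lower from compound 2 to compound 4 (beyond the scatter) and cyano in place of nitro gives a number 3.5 percentage points lower from compound 1 to compound 4 (within the scatter) at the same place on the ring. Nitro and cyano therefore read alike here, and of the three groups only ethyl holds the higher number, so the earlier drop is not peculiar to nitro. Nothing in hand accounts for the gap between ethyl and these two groups.

From the compounds shown here alone, whether a longer chain such as propyl keeps the level of ethyl remains open. So does where methoxy or an amine would fall at this place.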